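Acyclic amine variation on the shared core: compound 4

The source may hold more compounds than are shown below. What is called first, only, known or untested is meant among the compounds shown, and "the series" means these compounds.

Measured so far in an in vitro assay on 293-EBNA cells for binding affinity to corticotropin-releasing factor receptor 1 (Homo sapiens); a lower number here means a stronger inhibitor, a higher number a weaker inhibitor:
compound 1, `CCC(COC)N(C)c1nc(C)nc2c1nnn2-c1ccc(C(C)C)cc1Br`, gives 11.2 nM
compound 2, `Cc1nc(N2CCCC2)c2nnn(-c3ccc(C(C)C)cc3Br)c2n1`, gives 194 nM
compound 3, `CCCCN(CC)c1nc(C)nc2c1nnn2-c1ccc(C(C)C)cc1Br`, gives 7.5 nM

Compound 3 gives the lowest number of the three. Against this stands a 1.5-fold lower number from compound 1 to compound 3 (0.17 log units; within the scatter), so the two cannot be ranked against each other. The cyclic amine stands apart: a 26-fold lower number from compound 2 to compound 3 (1.41 log units; beyond the scatter), and likewise a 17-fold higher number from compound 1 to compound 2 (1.24 log units; beyond the scatter).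

Compound 4, `CCCC(CN(C)C)Nc1nc(C)nc2c1nnn2-c1ccc(C(C)C)cc1Br`, is not yet measured. Relative to compound 3 the change is a group of 9 heavy atoms (7 carbon, 2 nitrogen; no ring) in place of a group of 7 heavy atoms (6 carbon, 1 nitrogen; no ring), on an aromatic carbon. The entering group is again an open chain bearing an amine, with one hydrogen-bond donor and a second nitrogen in the chain.

Bearing on this step are the two steps that leave the open-chain amines and the one that closes them into a ring. Both acyclic amines of compound 1 and compound 3 give low numbers and sit within the scatter of each other, whereas the ring of compound 2 costs a large step. For the measured compounds named here, compound 4 keeps the open chain, so no large loss is expected; the added donor and second nitrogen have no precedent here, so some spread is allowed. The expected step is a 2.0-fold higher number from compound 3 to compound 4 (0.30 log units; within the scatter), with the value for compound 4 estimated at 15 nM, ranging from 4 nM to 60 nM.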

Compound 4, inhibition constant: 38.7 nM
The estimate for compound 4 lay 2.6-fold (0.41 log units) below the measured number; the range from low to high includes it.
By their numbers in this assay, from the lowest: compounds 3 and 1 (each within the scatter of the next); then compound 4; then compound 2.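

In this assay, an open chain on this aromatic carbon does not by itself keep the number low (a step of a 5.2-fold higher number from compound 3 to compound 4 (0.71 log units; beyond the scatter) and one of a 3.5-fold higher number from compound 1 to compound 4 (0.54 log units; beyond the scatter)), so the two earlier open-chain amines no longer speak for every open chain. Compound 4 still keeps a clear margin over the ring (a step of a 5.0-fold lower number from compound 2 to compound 4 (0.70 log units; beyond the scatter)), which places it between the two earlier open-chain amines and the pyrrolidin-1-yl compound. No measurement at hand accounts for this shift.

The entering group adds a hydrogen-bond donor and a second nitrogen together, and these compounds do not separate the two. A plain pentylamino chain, with the donor and no second nitrogen, and a tertiary amine chain ending in dimethylamino, with the second nitrogen and no donor, would each test one of them alone.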